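Aryl amide returns in place of a fluorophenethyl chain

A few compounds are considered here, and "the series" means these few. Any claim that something is new, unique, unknown or untested is made for them only; others in the source may bear on it.

Compound 1 `CC[C@@H](NC(=O)CC(C)C)C(=O)N1CCC(c2ccc(Cl)cc2)CC1` gives 152 nM in an assay on THP-1 cells for displacement of a labelled ligand from C-C chemokine receptor type 1 (Homo sapiens); on this read-out higher numbers stand for weaker inhibition and lower numbers for stronger inhibition.
Compound 2 `Cc1ccc(C(=O)N[C@@H](C(=O)N2CCC(c3ccc(Cl)cc3)CC2)C(C)C)cc1` gives 25 nM in this assay.
Compound 3 `CC(C)[C@@H](NC(=O)CCc1ccc(F)cc1)C(=O)N1CCC(c2ccc(Cl)cc2)CC1` gives 70 nM in this assay.
Compound 4 `Cc1ccccc1C(=O)N[C@@H](C(=O)N1CCC(c2ccc(Cl)cc2)CC1)C(C)C` is not yet measured in this assay.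

Among the three measured compounds, compound 3 stands second highest. Its nearest neighbour is compound 1, and the gap between them lies beyond the scatter; compound 2 stands furthest from it, with a lower number.

The step to compound 4 is 2-methylphenyl in place of 2-(4-fluorophenyl)ethyl on a carbonyl carbon. Among the measured compounds shown here, one measured step bears on it: a 2.8-fold higher number from compound 2 to compound 3 (0.45 log units; beyond the scatter), in which an aryl group bound directly to the carbonyl carbon was exchanged for a two-carbon chain ending in a fluorinated ring, and the number rose. Compound 4 reverses that kind of exchange, restoring a methyl-bearing aryl group directly on the carbonyl carbon, though the methyl now sits at a different position than in compound 2. A step back toward lower numbers is therefore expected, of a size similar to the one seen, with some allowance for the changed methyl position; the expected step is a 2.0-fold lower number from compound 3 to compound 4 (0.30 log units; within the scatter). Compound 4 is estimated at 35 nM, within a range from 12 nM to 100 nM.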

Compound 4, half-maximal inhibitory concentration: 32 nM
Compound 4: middle estimate off by 1.1-fold (0.04 log units), on the high side; low and high end bracket the measured number.
By their numbers in this assay, from the lowest: compounds 2 and 4 (each within the scatter of the next); then compound 3; then compound 1.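

In this assay, putting 2-methylphenyl in place of 2-(4-fluorophenyl)ethyl on the carbonyl carbon gives a 2.2-fold lower number from compound 3 to compound 4 (0.34 log units; beyond the scatter) and a step beyond the scatter. The earlier rise on going from a directly attached aryl group to the two-carbon chain therefore has a counterpart in the opposite direction, and with a different aryl group. The new pair also gives the first reading on where the methyl sits on that ring: 2-methylphenyl in place of 4-methylphenyl gives a 1.3-fold higher number from compound 2 to compound 4 (0.11 log units; within the scatter) in the same assay, so these two groups cannot be told apart here, and no measurement shown accounts for either step.

A methoxy group or a chlorine on the aryl ring, or a pyridine ring in its place, would show whether this position accepts more than a methyl-bearing phenyl. As far as these compounds go, it also remains open whether the chain length or the fluorine accounts for the gap between the chain and the directly attached aryl groups, a question on which a plain 2-phenylethyl group would bear.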